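This account rests on a few compounds, and the source may have more. Where it says the series, first, only, none or still open, it means among the compounds named here.

In a functional assay on A549 cells (Homo sapiens) for inhibition, read by sulforhodamine B assay, with a stated time of 48 h (on this read-out higher numbers stand for weaker inhibition of growth and lower numbers for stronger inhibition of growth), compound 1 `COc1ccc(C=C(C(=O)/C=C/c2ccc(O)c(OC)c2)C(=O)/C=C/c2ccc(O)c(OC)c2)c(OC)c1` gives 690 nM and compound 2 `COc1cc(/C=C/C(=O)C(=Cc2cccc(OC)c2OC)C(=O)/C=C/c2ccc(O)c(OC)c2)ccc1O` gives 420 nM, so these two values lie within the scatter of each other. Compound 3 `COc1cccc(C=C(C(=O)/C=C/c2ccc(O)c(OC)c2)C(=O)/C=C/c2ccc(O)c(OC)c2)c1` differs from compound 2 by hydrogen in place of methoxy on an aromatic carbon, with hydrogen in place of methoxy on an aromatic carbon, which turns 2,3-dimethoxyphenyl into 3-methoxyphenyl. Within the data shown here, the only measured step on this phenyl group is a 1.6-fold lower number from compound 1 to compound 2 (0.22 log units; within the scatter). Among the measured compounds shown here, no measured step removes a methoxy group, so no change beyond the scatter is expected in this assay. The estimated step is a 1.2-fold higher number from compound 2 to compound 3 (0.08 log units; within the scatter). Compound 3 is expected at 500 nM, within a range of 220 nM to 1200 nM.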

Compound 3, concentration for 50% growth inhibition: 640 nM
Beside the measured number, compound 3's estimate is 1.3-fold (0.11 log units) below it; measured number inside the range.
By their numbers in this assay, from the lowest: compounds 2, 3 and 1 (each within the scatter of the next).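

Hydrogen in place of methoxy on the aromatic carbon ortho to a large group and ortho to a methoxy group gives, in this assay, a 1.5-fold higher number from compound 2 to compound 3 (0.18 log units; within the scatter), so this methoxy group can go without a change beyond the scatter. Likewise, 3-methoxyphenyl in place of 2,4-dimethoxyphenyl gives a 1.1-fold lower number from compound 1 to compound 3 (0.03 log units; within the scatter). Nothing at hand explains this flat result. Open, going by these compounds, is whether an amine or a carboxylic acid on this aromatic carbon, or a longer chain in place of the remaining methoxy group, would move the number beyond the scatter.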